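Swapping the iodophenyl arm of a chalcone sulfone

The source may report more compounds than this note shows. Statements on the series, on what has been measured and on what is new or still open speak of the compounds shown alone.

The measured compounds:
- compound 1, `O=C(/C(=C\c1ccc(I)cc1)S(=O)(=O)c1ccc(Br)cc1)c1ccc(Br)cc1`, 1000 nM
- compound 2, `O=C(/C(=C\c1ccc(O)cc1O)Sc1ccccc1Br)c1ccc(Cl)cc1`, 50000 nM
- compound 3, `O=C(/C(=C\c1c[nH]c2ccc(Cl)cc12)SCc1ccc(F)cc1)c1ccc(Br)cc1`, 1000 nM

In a functional assay on DU-145 cells (Homo sapiens) for inhibition, read by trypan blue exclusion, with a stated time of 96 h (a higher number here means a weaker inhibitor of growth, a lower number a stronger inhibitor of growth), compound 1 gives 1000 nM, a number that matches compound 3 at the digits reported, with the two standing together at the low end of the three values. Compound 2, the compound furthest from it, gives a markedly higher number in this assay, a gap well beyond the usual scatter of the measurement. Going by the values given here, no single-change pair exists among the measured compounds. No step size within the series can be read directly.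

The unmeasured compound 4, `COc1ccc(/C=C(\C(=O)c2ccc(Br)cc2)S(=O)(=O)c2ccc(Br)cc2)c(F)c1`, keeps the core of compound 1 and changes one arm: 2-fluoro-4-methoxyphenyl in place of 4-iodophenyl on a double-bonded chain carbon bound to a double-bonded chain carbon. Among the compounds with values here, no measured pair isolates a change of this kind, so the expectation rests on the whole of the small set. Compound 4 is expected to give a number in this assay close to that of compound 1, with a step of a 1.5-fold higher number from compound 1 to compound 4 (0.18 log units; within the scatter) that is small and likely within the scatter, leaning if anywhere toward a slightly higher number. Compound 4 is therefore estimated at 1500 nM, within a range from 400 nM to 6000 nM.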

Compound 4, concentration for 50% growth inhibition: 10000 nM
For compound 4 the middle estimate is 6.7-fold (0.82 log units) below the measured one, and the stated range ends below it.
By their numbers in this assay, from the lowest: compounds 1 and 3 (each within the scatter of the next); then compound 4; then compound 2.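

In this assay, the arm on a double-bonded chain carbon bound to a double-bonded chain carbon turns out not to be a silent place on the shared core: 2-fluoro-4-methoxyphenyl in place of 4-iodophenyl gives a 10-fold higher number from compound 1 to compound 4 (1.00 log units; beyond the scatter). Going by these compounds alone, this is the first step that can be tied to a single change, since the earlier compounds differ from one another in more than one place and could show no effect of this arm alone. No evidence here bears on why this swap moves the number.

The fluorine and the methoxy group enter together, so the compounds shown do not tell whether one of them carries the step, whether both contribute, or whether the removal of the iodine alone would produce it. They also leave open how an amine or a carboxylic acid in place of the iodine would read on this arm, and whether a step of this size would recur on a core that carries a different group in place of the sulfone.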